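A few compounds are considered here, and "the series" means these few. Any claim that something is new, unique, unknown or untested is made for them only; others in the source may bear on it.

Compound 1 `O=C1NC(=S)/C(=C/c2ccc(Cl)cc2)S1` gives 10% in a functional assay on NCI-H292 cells (Homo sapiens) for cytotoxicity, read by MTT assay, with a stated time of 72 h, tested at 1.25 ug/mL; a higher number here means more inhibition of growth at the concentration tested, a lower number less inhibition of growth. Compound 2 `O=C1NC(=S)/C(=C/c2cccc(Cl)c2)S1` gives 3.35% in this assay and so stands at the low end of the two numbers, with compound 1 lying within the scatter of it. Compound 3 `O=C1NC(=S)/C(=C/c2ccc(Cl)c(Cl)c2)S1` differs from compound 2 in one place: chloro in place of hydrogen on an aromatic carbon. Going by the values given here, no step between measured compounds is available to size this change, so only a modest shift, if any, is expected. The estimate implies a step of a number 6.7 percentage points higher from compound 2 to compound 3 (within the scatter), not beyond the scatter. Compound 3 is expected to give 10%, with a range from 0% to 30%.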

Compound 3, percent growth inhibition at one concentration: 9.18%
The estimate for compound 3 lay 0.8 percentage points above the measured number; the range from low to high includes it.
By their numbers in this assay, from the lowest: compounds 2, 3 and 1 (each within the scatter of the next).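

Placing a chloro on the aromatic carbon ortho to a chloro group and para to a group of 8 heavy atoms gives, in this assay, a number 5.8 percentage points higher from compound 2 to compound 3 (within the scatter) and, read from the other chlorinated compound, a number 0.8 percentage points lower from compound 1 to compound 3 (within the scatter). Neither step separates the compound bearing two chloro groups from those bearing one, so this second chloro makes no readable difference here. No evidence is available that bears on this result. The compounds shown leave open whether a methoxy, an amine or a carboxylic acid at this position would give a different number, since chloro is the only group seen there.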